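Chloro in Place of Hydrogen: Expectation for Compound 4

A few compounds are considered here, and "the series" means these few. Any claim that something is new, unique, unknown or untested is made for them only; others in the source may bear on it.

Measured so far in a functional assay on A549 cells (Homo sapiens) for inhibition, read by sulforhodamine B assay, tested at 10 uM; a lower number here means less inhibition of growth, a higher number more inhibition of growth at the concentration tested:
compound 1 `COc1cc(C2CC(c3ccc(OCc4cn(Cc5ccc([N+](=O)[O-])cc5)nn4)cc3)=NN2C(C)=O)ccc1Oc1cn(Cc2ccc([N+](=O)[O-])cc2)nn1`: 29%
compound 2 `COc1ccc(C2CC(c3ccc(OCc4cn(Cc5ccc([N+](=O)[O-])cc5)nn4)cc3)=NN2C(C)=O)cc1`: 26%
compound 3 `COc1cc(C2CC(c3ccccc3)=NN2C(C)=O)ccc1OCc1cn(Cc2ccc([N+](=O)[O-])cc2)nn1`: 0%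

Compound 3 stands lowest of the three numbers in this assay. Its nearest neighbour is compound 2, whose number is higher by a margin beyond the usual scatter, and the furthest is compound 1, higher still, also beyond the scatter. For the measured compounds named here, neither compound 1 nor compound 2 differs from compound 3 in a single place, so no step of one change is available as a guide.

Compound 4 `COc1cc(C2CC(c3ccc(Cl)cc3)=NN2C(C)=O)ccc1OCc1cn(Cc2ccc([N+](=O)[O-])cc2)nn1` is compound 3 with one alteration: chloro in place of hydrogen on an aromatic carbon. Going by the values given here, no measured pair isolates this kind of change, so the size of the step is open. With a single heavy atom entering and nothing else moved, the expectation is a step of a number 8 percentage points higher from compound 3 to compound 4 (within the scatter) from compound 3, that is, no change beyond the scatter, with a slight lean upward kept within the range.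

For compound 4 in this assay the estimate is 8%, expected to fall between 0% and 22%.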

Compound 4, percent growth inhibition at one concentration: 0%
Compound 4: middle estimate off by 8 percentage points, on the high side; the measured number falls inside the stated range.
By their numbers in this assay, from the lowest: compounds 3 and 4 (each within the scatter of the next); then compounds 2 and 1 (each within the scatter of the next).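

In this assay, for the compounds shown here, the change from phenyl to 4-chlorophenyl gives no change at the digits printed from compound 3 to compound 4 (within the scatter), the first step that isolates a single place. Chloro in place of hydrogen on this aromatic carbon, para to a large group, adds no inhibition of growth beyond the scatter at the concentration tested, and compound 4 reads 0%. No data at hand bear on the reason for this result.

Still open, on these data alone, is whether a different group at this position, such as an amine or a carboxylic acid, would move the number. Also open, as far as these compounds go, is whether chloro would give the same step on another carbon of this ring or on a compound of the series with a number clearly above that of compound 3.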